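This account rests on a few compounds, and the source may have more. Where it says the series, first, only, none or still open, it means among the compounds named here.

Working notes on the series.

Compound 1 `COC(=O)[C@@H](CC(C)C)NC(=O)Cn1cc(C2=C(c3c[nH]c4ccccc34)C(=O)N(C)C2=O)c2ccccc21`, compound 2 `CC[C@H](C)[C@@H](NC(=O)Cn1cc(C2=C(c3c[nH]c4ccccc34)C(=O)N(C)C2=O)c2ccccc21)C(=O)OC` and compound 3 `COC(=O)C[C@@H](NC(=O)Cn1cc(C2=C(c3c[nH]c4ccccc34)C(=O)N(C)C2=O)c2ccccc21)C(=O)OC` share one core and differ only in the substituent on the saturated chain carbon bound to an amide-type nitrogen and a carbonyl carbon. In a functional assay on Bel-7402 cells (Homo sapiens) for cytotoxicity, read by MTT assay, with a stated time of 24 h (a lower number here means a stronger inhibitor, a higher number a weaker inhibitor), compound 1 gives 42400 nM. Compound 2 reaches only the assay limit of > 100000 nM in this assay. Compound 3 gives 9360 nM in this assay and stands lowest of the two numbers shown, with a 4.5-fold lower number from compound 1 to compound 3 (0.66 log units; beyond the scatter) and an at least 10-fold lower number from compound 2 to compound 3 (1.02 log units; beyond the scatter); the remaining step is an at least 2.3-fold higher number from compound 1 to compound 2 (0.37 log units; beyond the scatter).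

Compound 4 `COC(=O)[C@@H](CO)NC(=O)Cn1cc(C2=C(c3c[nH]c4ccccc34)C(=O)N(C)C2=O)c2ccccc21` is not yet measured. The change is hydroxy in place of methoxycarbonyl on a saturated chain carbon, two bonds along the chain from an amide-type nitrogen and a carbonyl carbon. The step bearing on it is a 4.5-fold lower number from compound 1 to compound 3 (0.66 log units; beyond the scatter), in which gaining methoxycarbonyl at this position gave a modest gain; losing it again for hydroxy is expected to give back part of that, so a modest rise in this assay is expected, a 2.4-fold higher number from compound 3 to compound 4 (0.37 log units; beyond the scatter). Compound 4 is expected near 22000 nM, within 7000 nM to 65000 nM.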

Compound 4, half-maximal inhibitory concentration: 67200 nM
Estimate against measurement, compound 4: 3.1-fold (0.48 log units) below; measured number outside the range, above it.
By their numbers in this assay, from the lowest: compound 3; then compounds 1 and 4 (each within the scatter of the next). At a limit, above all of these: compound 2.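

In this assay, replacing methoxycarbonyl with hydroxy gives a 7.2-fold higher number from compound 3 to compound 4 (0.86 log units; beyond the scatter), so the lowest number in the series is not kept once the methoxycarbonyl is gone from this place. Hydroxy in place of isopropyl at this place gives a 1.6-fold higher number from compound 1 to compound 4 (0.20 log units; within the scatter), so the two are not told apart. This leaves compound 3 as the only one whose number stands clear of those of all the other compounds shown. Compound 2 stands at a limit and not at a number: the limit of > 100000 nM in this assay, at which 1 of the 4 values shown sits. Hydroxymethyl in place of sec-butyl gives an at least 1.4-fold lower number from compound 2 to compound 4 (0.17 log units; that floor lies within the scatter), so this step cannot be read.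

As far as these compounds go, whether the low number of compound 3 would survive a carboxylic acid or a primary amide in place of the methoxycarbonyl remains open. Also open, from the compounds shown here alone, is how an amine or a longer chain ending in methoxycarbonyl would read at this place.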